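This account rests on a few compounds, and the source may have more. Where it says the series, first, only, none or still open, it means among the compounds named here.

For the measured compounds named here, compound 3 `CC(C)(C)OC(=O)N1CCC(O[C@H]2CC[C@H](Oc3cnc(S(C)(=O)=O)cn3)CC2)CC1` stands at the top of the three numbers so far in a functional assay on isolated protein for agonist activity at Glucose-dependent insulinotropic receptor (Rattus norvegicus), read by HTRF and cAMP accumulation (a higher number here means a larger maximal response, a lower number a smaller maximal response), where compound 3 gives 110%; the gaps to the other two lie within the scatter, so no order among them can be claimed. Compound 2 `CC(C)(C)OC(=O)N1CCC(O[C@H]2CC[C@H](Oc3ccc(S(C)(=O)=O)cn3)CC2)CC1` gives 108% in this assay, and compound 1 `CC(C)(C)OC(=O)N1CCC(O[C@H]2CC[C@H](Oc3ccc(C#N)cc3)CC2)CC1` gives 106%. The steps that lead here are all small: a number 2 percentage points higher from compound 1 to compound 2 (within the scatter), a number 4 percentage points higher from compound 1 to compound 3 (within the scatter) and a number 2 percentage points higher from compound 2 to compound 3 (within the scatter). Each of these swaps one aromatic ring on the oxygen on the saturated carbon for another carrying the methylsulfonyl group or the nitrile, and none moves the maximal response beyond the scatter.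

Compound 4 `CC(C)(C)OC(=O)N1CCC(O[C@H]2CC[C@H](Oc3ccc(S(C)(=O)=O)nn3)CC2)CC1` is the next member. The change from compound 3 is 6-(methylsulfonyl)pyridazin-3-yl in place of 5-(methylsulfonyl)pyrazin-2-yl on an oxygen on a saturated carbon. All three measured steps bear on this change, since each exchanges the aromatic ring at the same oxygen, and each was within the scatter. On that basis no step beyond the scatter is expected in this assay; the step from compound 3 to compound 4 is estimated at a number 1 percentage points lower from compound 3 to compound 4 (within the scatter). For compound 4 the expected value in this assay is 109%, with a range from 99% to 119%, pending the measurement.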

Compound 4, largest response reached (Emax), in percent of the reference or control that the assay uses: 86%
For compound 4 the middle estimate is 23 percentage points above the measured one; measured number outside the range, below it.
By their numbers in this assay, from the lowest: compound 4; then compounds 1, 2 and 3 (each within the scatter of the next).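

For the compounds shown here, the 6-(methylsulfonyl)pyridazin-3-yl group on an oxygen on a saturated carbon gives a number 24 percentage points lower from compound 3 to compound 4 (beyond the scatter) and a number 22 percentage points lower from compound 2 to compound 4 (beyond the scatter) and a number 20 percentage points lower from compound 1 to compound 4 (beyond the scatter) in this assay and these are the first steps beyond the scatter, so the aromatic ring at this place is not freely exchangeable, although the earlier exchanges suggested that it might be. The 5-(methylsulfonyl)pyrazin-2-yl and 6-(methylsulfonyl)pyridazin-3-yl groups have the same atoms, joined differently, and the same counts of hydrogen-bond donors and acceptors, so the way the atoms are joined within this group is enough to separate compound 3 from compound 4, which those counts cannot show. Nothing at hand accounts for this difference.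

Going by these compounds alone, compound 4 is the only compound with this ring, so it remains open whether the lower maximal response stays when an amine or a carboxylic acid takes the place of the methylsulfonyl group on it. Going by these compounds, it is also open how the other parts of the shared core would alter this step, since they are the same in all four compounds.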